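This account rests on a few compounds, and the source may have more. Where it says the series, first, only, none or still open, it means among the compounds named here.

Of the compounds shown here, three sharing one core have been tested in a functional assay on NCI-H1299 cells (Homo sapiens) for antiproliferative activity, read by XTT assay, with a stated time of 72 h; on this read-out higher numbers stand for weaker inhibition and lower numbers for stronger inhibition. Compound 1 `COc1ccc(-c2cc3ccccc3nc2/C=C/C(=O)c2ccc(F)cc2)cc1` gives 820 nM. Compound 2 `COc1ccc(-c2cc3ccccc3nc2/C=C/C(=O)c2ccc(O)cc2)cc1` gives 8970 nM, and compound 3 `COc1ccc(C(=O)/C=C/c2nc3ccccc3cc2-c2ccc(OC)cc2)cc1` gives 6420 nM. The changes among them all sit on the ring carrying the carbonyl: an 11-fold higher number from compound 1 to compound 2 (1.04 log units; beyond the scatter), a 7.8-fold higher number from compound 1 to compound 3 (0.89 log units; beyond the scatter), and a 1.4-fold lower number from compound 2 to compound 3 (0.15 log units; within the scatter). On these numbers compound 3 stands second highest of the three, though its gap to compound 2 lies within the scatter, while its gap to compound 1 lies well beyond it.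

Compound 4 `COc1ccc(-c2cc3ccccc3nc2/C=C/C(=O)c2ccc(OC)cc2OC)cc1` differs from compound 3 by methoxy in place of hydrogen on an aromatic carbon. Within the data shown here, no measured step adds a group at this position, ortho to a large group and meta to a methoxy group. Among the measured compounds shown here, the steps that come nearest are a 7.8-fold higher number from compound 1 to compound 3 (0.89 log units; beyond the scatter), which brought in the first methoxy group on this ring, and a 1.4-fold lower number from compound 2 to compound 3 (0.15 log units; within the scatter), which only capped a hydroxy group. For the measured compounds named here, both compounds bearing a methoxy group here, compound 2 and compound 3, show high numbers, and a second methoxy group on the same ring has no precedent among them. The expectation is therefore a step of a 1.1-fold lower number from compound 3 to compound 4 (0.03 log units; within the scatter), within the scatter. Compound 4 is estimated at 6000 nM, in a range from 2000 nM to 18000 nM.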

Compound 4, half-maximal inhibitory concentration: 3770 nM
Beside the measured number, compound 4's estimate is 1.6-fold (0.20 log units) above it; measured number inside the range.
By their numbers in this assay, from the lowest: compound 1; then compounds 4, 3 and 2 (each within the scatter of the next, the first and the last beyond it).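

Adding a methoxy group on this aromatic carbon, ortho to a large group and meta to a methoxy group, turns 4-methoxyphenyl into 2,4-dimethoxyphenyl, and in this assay the result is a 1.7-fold lower number from compound 3 to compound 4 (0.23 log units; within the scatter) so this second methoxy group can be accommodated without a change that can be told from the scatter. Compared with the other groups on the carbonyl carbon, 2,4-dimethoxyphenyl gives a distinction that the single methoxy group of compound 3 did not give against 4-hydroxyphenyl, with a 2.4-fold lower number from compound 2 to compound 4 (0.38 log units; beyond the scatter) yet it stays short of 4-fluorophenyl, with a 4.6-fold higher number from compound 1 to compound 4 (0.66 log units; beyond the scatter) and so does not restore the lowest number in the set. Nothing measured on these compounds offers an explanation for these steps.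

The compounds shown leave open whether a methoxy group at this same position would have any effect on the 4-fluorophenyl ring of compound 1, which holds the lowest number. They also leave open how this position would respond to a group of another kind, such as an amine, a carboxylic acid or a longer chain like butoxy.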